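The compounds below may be only part of what the source reports. "The series", "measured", "known", "first", "only" and "open" are said of these compounds alone.

In a functional assay on HeLa cells (Homo sapiens) for inhibition, read by sulforhodamine B assay (a lower number here means a stronger inhibitor, a higher number a weaker inhibitor), compound 3 `O=C1C=C(NC2CCCCC2)C(=O)c2c1nc1n2[C@H]2OC[C@@H](O)[C@H]2OC1` sits only at a limit of the assay, giving > 16000 nM. Of the three compounds measured, it alone stands at that limit (the limit of > 16000 nM in this assay, at which 1 of the 3 values shown sits). Compound 1 `COc1cccc(NC2=CC(=O)c3nc4n(c3C2=O)[C@H]2OC[C@@H](O)[C@H]2OC4)c1` gives 4280 nM, and compound 2 `O=C1C=C(Nc2cccc(Cl)c2)C(=O)c2c1nc1n2[C@H]2OC[C@@H](O)[C@H]2OC1` gives 6040 nM, the two lying within the scatter of each other a 1.4-fold higher number from compound 1 to compound 2 (0.15 log units; within the scatter). The change to compound 4 `COc1ccc(NC2=CC(=O)c3nc4n(c3C2=O)[C@H]2OC[C@@H](O)[C@H]2OC4)cc1` is 4-methoxyphenyl in place of cyclohexyl on an amine nitrogen. Going by the values given here, two measured steps bear on it, both running the other way: an at least 3.7-fold higher number from compound 1 to compound 3 (0.57 log units; beyond the scatter) and an at least 2.6-fold higher number from compound 2 to compound 3 (0.42 log units; beyond the scatter), each putting cyclohexyl in place of an aromatic ring on the amine nitrogen and weakening inhibition at least modestly. Restoring an aromatic ring is therefore expected to lower the number, an expected step of an at least 3.2-fold lower number from compound 3 to compound 4 (0.50 log units; beyond the scatter). Compound 4 is estimated at 5000 nM, with a range from 1500 nM to 16000 nM.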

Compound 4, half-maximal inhibitory concentration: 4780 nM
Beside the measured number, compound 4's estimate is 1.0-fold (0.02 log units) above it; low and high end bracket the measured number.
By their numbers in this assay, from the lowest: compounds 1, 4 and 2 (each within the scatter of the next). At a limit, above all of these: compound 3.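

A second kind of substituted ring on the amine nitrogen confirms that, in this assay, an aromatic ring there beats cyclohexyl: an at least 3.3-fold lower number from compound 3 to compound 4 (0.52 log units; beyond the scatter); compound 3 is only a limit, so the true gap may be larger. The ring's substituent pattern is not yet resolved, since 3-methoxyphenyl and 4-methoxyphenyl cannot be told apart, a 1.1-fold higher number from compound 1 to compound 4 (0.05 log units; within the scatter), nor can 3-chlorophenyl and 4-methoxyphenyl, a 1.3-fold lower number from compound 2 to compound 4 (0.10 log units; within the scatter). The limit itself is this: the limit of > 16000 nM in this assay, at which 1 of the 4 values shown sits.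

From the compounds shown here alone, whether an unsubstituted phenyl ring would perform the same remains open. So does the effect of a ring carrying an amine or a carboxylic acid.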